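This account rests on a few compounds, and the source may have more. Where it says the series, first, only, none or still open, it means among the compounds named here.

Measured so far in a functional assay on SK-BR-3 cells (Homo sapiens) for inhibition, read by CellTiter-Glo, with a stated time of 72 h; on this read-out higher numbers stand for weaker inhibition and lower numbers for stronger inhibition:
- compound 1, `CC(C)c1nn(-c2ccc(C(N)=O)c(N[C@H]3CC[C@H](O)CC3)c2)c2nccc(-n3cnc(-c4ccncc4)c3)c12`, gives 165 nM
- compound 2, `COc1cncc(-c2ccnc3c2c(C(C)C)nn3-c2ccc(C(N)=O)c(N[C@H]3CC[C@H](O)CC3)c2)c1`, gives 451 nM
- compound 3, `CC(C)c1nn(-c2ccc(C(N)=O)c(N[C@H]3CC[C@H](O)CC3)c2)c2nccc(-c3ccccc3)c12`, gives only a limit, > 10000 nM

Compound 3 stands at the weak end of the series: in this assay the value for compound 3 is a limit and not a number, at the limit of > 10000 nM in this assay, at which 1 of the 3 values shown sits. The two steps leading into it are both large: an at least 60-fold higher number from compound 1 to compound 3 (1.78 log units; beyond the scatter) and an at least 22-fold higher number from compound 2 to compound 3 (1.34 log units; beyond the scatter). By comparison, the exchange among the two measured aryl groups is smaller, a 2.7-fold higher number from compound 1 to compound 2 (0.44 log units; beyond the scatter).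

Compound 4, `CC(C)c1nn(-c2ccc(C(N)=O)c(N[C@H]3CC[C@H](O)CC3)c2)c2nccc(-c3ccc4ccccc4c3)c12`, carries the change (naphthalen-2-yl in place of phenyl on an aromatic carbon). Going by the values given here, no measured step covers a naphthalen-2-yl group, so nothing speaks directly to this exchange. What the series does show is that phenyl at this position sits beyond the assay limit, far behind compound 1 and compound 2. Among the compounds with values here, with no comparable step available, a return into the measurable range cannot be expected from the numbers alone; the estimate for compound 4 therefore stays near the limit, with a wide range, and the step of an at least 1.2-fold lower number from compound 3 to compound 4 (0.09 log units; that floor lies within the scatter) is the expected consequence. Compound 4 is estimated at 8000 nM, between 2000 nM and 30000 nM.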

Compound 4, half-maximal inhibitory concentration: > 10000 nM
Compound 4 ended at the assay's limit (the forecaster's own chance of this, stated with the estimate: 50%); middle value at least 1.2-fold (0.09 log units) from the limit.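

In this assay compound 4 gives > 10000 nM, which is a limit and not a number. Replacing phenyl with naphthalen-2-yl, which adds a second six-membered aromatic ring of carbon only, does not return this position to the measurable range, and the gaps to the two groups with ring nitrogen remain large: an at least 22-fold higher number from compound 2 to compound 4 (1.34 log units; beyond the scatter), and an at least 60-fold higher number from compound 1 to compound 4 (1.78 log units; beyond the scatter). Among the four compounds, the two groups of carbon only, in compound 3 and compound 4, now end at the limit, while the two groups with ring nitrogen, in compound 1 and compound 2, give numbers, and the step from compound 3 to compound 4 cannot be read, with a limit on each side: the limit of > 10000 nM in this assay, at which 2 of the 4 values shown sit.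

Still open, from the compounds shown here alone, is whether the ring nitrogen itself accounts for this split, a question that a plain pyridin-3-yl group, or a phenyl group carrying an amine or a carboxylic acid, would address. Also open, going by these compounds, is how far compound 3 and compound 4 lie beyond the limit, so the larger aromatic group cannot be ranked against phenyl.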